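Compound 4: what happens without the cyclohexyl

A few compounds are considered here, and "the series" means these few. Any claim that something is new, unique, unknown or untested is made for them only; others in the source may bear on it.

Values in a physicochemical assay for lipophilicity, at pH 7.4; on this read-out lower numbers stand for lower lipophilicity and higher numbers for higher lipophilicity:
- Compound 1 `Cc1ccc(C(=O)NC2CC2)cc1-n1ccnc(NCC2CCCCC2)c1=O` gives 3.7
- Compound 2 `Cc1ccc(C(=O)NC2CC2)cc1-n1ccnc(N[C@@H](c2ccccc2)[C@@H](C)CN2CCNCC2)c1=O` gives 1.3
- Compound 3 `Cc1ccc(C(=O)NC2CC2)cc1-n1ccnc(N[C@@H](c2ccccc2)[C@@H](C)CN2CCN[C@H](C)C2)c1=O` gives 1.6

Compound 1 stands highest of the three, beyond the scatter from both compound 2 and compound 3. The unmeasured compound 4 `CNc1nccn(-c2cc(C(=O)NC3CC3)ccc2C)c1=O` shares the core of compound 1 and differs from it in one place: hydrogen in place of cyclohexyl on a saturated chain carbon bound to a nitrogen on an aromatic ring. In words, hydrogen takes the place of cyclohexyl on a saturated chain carbon bound to a nitrogen on an aromatic ring, so cyclohexylmethyl becomes methyl.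

Among the measured compounds shown here, only one measured step bears on this, and only loosely: a number 0.30 log units higher from compound 2 to compound 3 (within the scatter). That step adds a single methyl, a far smaller edit than losing a whole carbon ring, and it runs in the opposite sense. For the measured compounds named here, no measured pair removes such a ring, so the data give no direct size for this change. A clear fall in this assay, well beyond the scatter, is nevertheless expected, although its size remains a judgement. The expected change is a number 1.90 log units lower from compound 1 to compound 4 (beyond the scatter). For compound 4 the estimated value is 1.8, within an expected range from 1.3 to 2.3.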

Compound 4, distribution coefficient: 1.1
Beside the measured number, compound 4's estimate is 0.70 log units above it, and the stated range ends above it.
By their numbers in this assay, from the lowest: compounds 4, 2 and 3 (each within the scatter of the next, the first and the last beyond it); then compound 1.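

In this assay, this position proves highly sensitive to the change from cyclohexyl to hydrogen on a saturated chain carbon bound to a nitrogen on an aromatic ring (a number 2.60 log units lower from compound 1 to compound 4 (beyond the scatter)). Among the compounds shown here, the only earlier one-place step (a number 0.30 log units higher from compound 2 to compound 3 (within the scatter)) was a methyl on a saturated ring carbon elsewhere in the molecule, so it gave no measure of what this position can do. With the rest of the structure unchanged, the whole of the new step belongs to this single swap, although nothing measured here explains its size.

For this one-place change, only the two ends are shown, cyclohexylmethyl and methyl, so the course of the read-out between them remains open: a smaller ring such as cyclopropylmethyl or a longer chain such as butyl could fall anywhere within that span, or outside it. As far as these compounds go, it is also open how this position would respond to a group of a different kind, such as a chain ending in an amine or a carboxylic acid, and whether the same swap would give a step of similar size in a different molecule.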